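Anilinothiophene series: methyl added to the anilino ring

This account rests on a few compounds, and the source may have more. Where it says the series, first, only, none or still open, it means among the compounds named here.

Measured compounds:
compound 1 `COC(=O)c1c(Nc2ccc(C)cc2)sc(C(=O)c2ccc(C)cc2)c1C`, a functional assay, with a stated time of 150 min, tested at 20 ug/mL; on this read-out higher numbers stand for a stronger effect at the one concentration tested and lower numbers for a weaker effect: "not active" (no number reported)
compound 2 `COc1ccc(C(=O)c2sc(Nc3ccc(C)cc3)c(C(=O)O)c2C)cc1`, this assay: "not active" (no number reported)
compound 3 `Cc1ccc(C(=O)c2sc(Nc3ccccc3)c(C(=O)O)c2C)cc1`, this assay: 2.68%

Among the compounds with values here, compound 3 stands as the only member of the series with a number in this assay; compound 1 and compound 2 are recorded without one. Its value is small and, as a single reading, close to the usual scatter of such measurements. Within the data shown here, no step between measured compounds is available, since the three differ in more than one place.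

Compound 4 `Cc1ccc(Nc2sc(C(=O)c3ccc(C)cc3)c(C)c2C(=O)O)cc1` is the next member. It differs from compound 3 as follows: methyl in place of hydrogen on an aromatic carbon. The expectation for the step from compound 3 to compound 4 in this assay is a number 0.3 percentage points higher from compound 3 to compound 4 (within the scatter), that is, nothing beyond the scatter in either direction, because compound 3 gives 2.68% and the two compounds carrying the (4-methylphenyl)amino group, compound 1 and compound 2, were both recorded without activity. Compound 4 is therefore estimated at 3%, with a range from 0% to 12%.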

Compound 4, a percentage reported as activity, at one concentration (the size of the read-out at that concentration, not a potency): "not active" (no number reported)
Compound 4: no number reported; the estimate stays without a comparison.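

Within the data shown here, compound 4 is recorded as "not active" (no number reported) and carries no number, so no step from compound 3 to compound 4 can be read. As far as these compounds go, whether phenyl to 4-methylphenyl on the anilino group changes the read-out at all stays open. No measurement shown bears on this result.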